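The source may hold more compounds than are shown below. What is called first, only, known or untested is meant among the compounds shown, and "the series" means these compounds.

In a functional assay on HL-60 cells (Homo sapiens) for antiproliferative activity, with a stated time of 72 h (a higher number here means a weaker inhibitor, a lower number a stronger inhibitor), two compounds on a shared core have been measured so far. Compound 1 (`Nc1ncnn2c([C@@H]3O[C@H](CO)[C@@H](O)[C@H]3O)cc(-c3ccc(F)cc3)c12`), with 4-fluorophenyl, gives 68300 nM in this read-out. Compound 2 (`Nc1ncnn2c([C@@H]3O[C@H](CO)[C@@H](O)[C@H]3O)cc(-c3ccoc3)c12`), with furan-3-yl, gives 500 nM and holds the lower of the two numbers. Compound 3 (`Nc1ncnn2c([C@@H]3O[C@H](CO)[C@@H](O)[C@H]3O)cc(-c3ccccc3Cl)c12`) follows, with 2-chlorophenyl in place of furan-3-yl on an aromatic carbon. Among the compounds with values here, the one measured step at this place is a 140-fold lower number from compound 1 to compound 2 (2.14 log units; beyond the scatter) and it is large. Within the data shown here, that step leaves a phenyl group for furan-3-yl, whereas compound 3 returns to a phenyl group with a different substituent, and no measured compound shows what that substituent does. A large rise in the number is therefore expected, somewhat smaller than that measured step. The expected change is (a 40-fold higher number from compound 2 to compound 3 (1.60 log units; beyond the scatter)) in this assay and remains uncertain. Compound 3 is estimated at 20000 nM (expected range 3000 nM to 100000 nM).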

Compound 3, half-maximal inhibitory concentration: > 100000 nM
Compound 3: a limit, no number (the forecaster's own chance of this, stated with the estimate: 20%); middle value at least 5.0-fold (0.69 log units) away from the limit.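

In this assay compound 3 reaches only a limit of the assay, not a number: the limit of > 100000 nM in this assay, at which 1 of the 3 values shown sits. Replacing furan-3-yl with 2-chlorophenyl on this aromatic carbon gives an at least 200-fold higher number from compound 2 to compound 3 (2.30 log units; beyond the scatter), so a second substituted phenyl group also lies far from compound 2 in this read-out. Between the two phenyl groups the result gives only an at least 1.4-fold higher number from compound 1 to compound 3 (0.16 log units; that floor lies within the scatter), which sets no order between compound 1 and compound 3, although both carry a substituted phenyl group and both show far higher numbers than furan-3-yl does in compound 2.

The compounds shown leave open where an unsubstituted phenyl group would fall relative to these three. They also leave open whether the ring oxygen of furan-3-yl matters here, a question that a thiophene ring at this carbon could answer.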